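This account rests on a few compounds, and the source may have more. Where it says the series, first, only, none or still open, it means among the compounds named here.

In an ADME assay on L929 cells (Mus musculus) for cytotoxicity, read by resazurin assay, with a stated time of 72 h (a higher number here means a weaker inhibitor, a lower number a stronger inhibitor), two compounds have been measured so far:

Compound 1, `O=C(c1ccccc1)c1ccn(-c2ccc3c(c2)B(O)OC3)c1`: > 10 ug/mL
Compound 2, `COc1ccc(C(=O)c2ccn(-c3ccc4c(c3)B(O)OC4)c2)cc1`: > 10 ug/mL

Compound 2 stands at the edge of what this assay reports: its value of > 10 ug/mL is a limit, not a number. Compound 1 likewise gives > 10 ug/mL, again a limit. For the measured compounds named here, the single recorded step between them, a step that the two limits leave unreadable from compound 1 to compound 2, therefore cannot be sized, due to the limit of > 10 ug/mL in this assay, at which 2 of the 2 values shown sit.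

Compound 3, `O=C(c1ccc(O)cc1)c1ccn(-c2ccc3c(c2)B(O)OC3)c1`, has not yet been measured in this assay. It differs from compound 2 by hydrogen in place of methyl on an oxygen on an aromatic ring. Going by the values given here, no measured step covers this particular change; the only step available is the unreadable one from compound 1 to compound 2, which gives no direction and no size. With both measured compounds resting at the same limit, there is nothing that points to a step beyond the scatter in either direction. The step from compound 2 to compound 3 is therefore expected to be a step that the limit leaves unreadable from compound 2 to compound 3. For compound 3 the estimate in this assay is 15 ug/mL, within a range from 5 ug/mL to 50 ug/mL, with a good chance that only a limit is reported once more.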

Compound 3, half-maximal inhibitory concentration: > 10 ug/mL
Compound 3 gave a limit, no number; the forecaster's own chance of this, stated with the estimate: 75%; the middle value is on the limit's open side.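

Compound 3 gives > 10 ug/mL in this assay, which is a limit and not a number. No step among compound 1, compound 2 and compound 3 can therefore be read, due to one shared ceiling: the limit of > 10 ug/mL in this assay, at which 3 of the 3 values shown sit.

The compounds shown leave open whether hydrogen, methoxy and hydroxy differ at all in this assay.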